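Working notes on compounds 1 to 4

The source may hold more compounds than are shown below. What is called first, only, known or untested is meant among the compounds shown, and "the series" means these compounds.

Compound 1 `Clc1ccc(-c2cn3nc(Cl)sc3n2)cc1` gives > 250000 nM in an ADME assay on CCRF-CEM cells (Homo sapiens) for cytotoxicity, with a stated time of 72 h; on this read-out higher numbers stand for weaker inhibition and lower numbers for stronger inhibition; this is a limit of the assay.
Compound 2 `Clc1ccc(Cc2nn3cc(-c4ccc(Br)cc4)nc3s2)cc1` gives > 250000 nM in this assay; this is a limit of the assay.
Compound 3 `COc1ccc(-c2cn3nc(Cl)sc3n2)cc1` gives > 250000 nM in this assay; this is a limit of the assay.

Among the measured compounds shown here, every value so far is a limit: the limit of > 250000 nM in this assay, at which 3 of the 3 values shown sit. For the measured compounds named here, the one measured pair that differs in a single place gives a step that the two limits leave unreadable from compound 1 to compound 3, and the two limits leave its size unreadable. Compound 2 stands at the limit of this assay, where the two other values shown also sit; no number separates it from them.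

Compound 4 `Clc1ccc(Cc2nn3cc(-c4ccc(Cl)cc4Cl)nc3s2)cc1` differs from compound 2 by 2,4-dichlorophenyl in place of 4-bromophenyl on an aromatic carbon. Going by the values given here, no measured step bears on this change; the only step recorded concerns a different substitution and its size is not readable.

With all three values at the limit, the expectation for this assay is that compound 4 also yields no readable number, so the expected step that the limit leaves unreadable from compound 2 to compound 4 is none beyond the scatter. Compound 4 is estimated at 300000 nM, with a range from 100000 nM to 1000000 nM, most likely reported again as a limit.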

Compound 4, half-maximal inhibitory concentration: > 250000 nM
Compound 4 was reported as a limit; the forecaster's own chance of this, stated with the estimate: 85%; the middle value lies beyond the limit too.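

In this assay compound 4 gives > 250000 nM, which is a limit of the assay, so no step from compound 2 to compound 4 can be read: the limit of > 250000 nM in this assay, at which 4 of the 4 values shown sit.

The compounds shown leave open whether any change to these structures gives a readable number in this assay, and whether 2,4-dichlorophenyl and 4-bromophenyl differ at all.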